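Aryl swap on the enone chain of the shared core

The compounds below may be only part of what the source reports. "The series", "measured", "known", "first", "only" and "open" are said of these compounds alone.

In a functional assay on HCT-116 cells (Homo sapiens) for antiproliferative activity, read by MTT assay, with a stated time of 24 h (on this read-out higher numbers stand for weaker inhibition and lower numbers for stronger inhibition), compound 1 `COc1ccc(C(=O)/C=C/c2ccc([N+](=O)[O-])cc2)c2c1C=CC(C)(C)O2` gives 8880 nM. Compound 2 `COc1ccc(C(=O)/C=C/c2ccsc2)c2c1C=CC(C)(C)O2` reaches only a limit of this assay, > 10000 nM, so its standing rests on the limit of > 10000 nM in this assay, at which 1 of the 2 values shown sits, rather than on a number. For the measured compounds named here, the single measured step, an at least 1.1-fold higher number from compound 1 to compound 2 (0.05 log units; that floor lies within the scatter), bears on the change at hand. Compound 3 `COc1ccccc1/C=C/C(=O)c1ccc(OC)c2c1OC(C)(C)C=C2` differs from compound 2 by 2-methoxyphenyl in place of thiophen-3-yl on a double-bonded chain carbon bound to a double-bonded chain carbon. Going by the values given here, since the one measured aryl swap on that chain carbon stayed within the scatter, no step beyond the scatter is expected in this assay. The estimated step is a number no higher from compound 2 to compound 3 (the limit leaves the size open). Compound 3 is therefore expected near 10000 nM, within 3000 nM to 30000 nM.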

Compound 3, half-maximal inhibitory concentration: > 10000 nM
Compound 3 gave a limit, no number; the forecaster's own chance of this, stated with the estimate: 45%; the middle value lies on the limit itself.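

With 2-methoxyphenyl on the double-bonded chain carbon, a six-membered aromatic ring of carbon only also ends at the limit in this assay: compound 3 gives > 10000 nM, a limit and not a number. Replacing 4-nitrophenyl with 2-methoxyphenyl gives an at least 1.1-fold higher number from compound 1 to compound 3 (0.05 log units; that floor lies within the scatter), so this second aryl swap also shows no step beyond the scatter. The step from compound 2 to compound 3 cannot be read, and the series now gathers at one ceiling: the limit of > 10000 nM in this assay, at which 2 of the 3 values shown sit.

On these data alone, whether any aryl group here gives a value clearly under that limit stays open. A dimethylamino group or a carboxylic acid on the phenyl ring at this chain carbon would test that.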